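A few compounds are considered here, and "the series" means these few. Any claim that something is new, unique, unknown or untested is made for them only; others in the source may bear on it.

Series notes. Compound 3 `Fc1ccc(-c2cn([C@@H]3CN4CCC3CC4)nn2)cc1` sets the low end of the numbers gathered so far: in an assay on HEK293 cells for displacement of a labelled ligand from Neuronal acetylcholine receptor; alpha3/beta4 (Homo sapiens), read by scintillation counting, with a stated time of 120 min (on this read-out lower numbers stand for stronger inhibition and higher numbers for weaker inhibition), compound 3 gives 3.09 nM. Compound 1 `c1ccc(COc2cccc(-c3cn([C@@H]4CN5CCC4CC5)nn3)c2)cc1` carries a benzyloxy group where compound 3 carries fluoro, and in this assay compound 1 gives 6.67 nM, a higher number than compound 3. Compound 2 `Fc1ccc(-c2cn(C3CN4CCC3CC4)nn2)cc1` shares every atom and bond with compound 3, and in this assay compound 2 gives 8.5 nM; the step of a 2.8-fold lower number from compound 2 to compound 3 (0.44 log units; beyond the scatter) goes with the fact that one of compounds 2 and 3 is drawn with a defined configuration and the other without, at the place where they differ.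

Compound 4 `Oc1ccc(-c2cn([C@@H]3CN4CCC3CC4)nn2)cc1` is the next member to test: hydroxy in place of fluoro on an aromatic carbon. For the measured compounds named here, no measured step touches this change directly. Going by the values given here, the single step measured, a 2.8-fold lower number from compound 2 to compound 3 (0.44 log units; beyond the scatter), concerns the stereocentre on the saturated ring and not the aromatic substituent, and the pair compound 1 / compound 3 alters the same aromatic carbon but with a different group, so it offers only its two numbers as context. The expected step in this assay is therefore kept small, a 2.3-fold higher number from compound 3 to compound 4 (0.36 log units; beyond the scatter), with the direction left open and only a slight lean toward a higher number. Compound 4 is expected to give 7 nM, within a range from 2.5 nM to 20 nM.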

Compound 4, inhibition constant: 2.48 nM
For compound 4 the middle estimate is 2.8-fold (0.45 log units) above the measured one; measured number below the stated range.
By their numbers in this assay, from the lowest: compounds 4 and 3 (each within the scatter of the next); then compounds 1 and 2 (each within the scatter of the next).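

In this assay, for the compounds shown here, the new pair gives a 1.2-fold lower number from compound 3 to compound 4 (0.10 log units; within the scatter) and so offers the first direct reading of a small swap on this aromatic carbon, para to a large group. Hydroxy and fluoro cannot be told apart there, even though hydroxy brings 1 hydrogen-bond donor and 1 hydrogen-bond acceptor where fluoro has none. Going by these compounds alone, earlier, the only change to an aromatic substituent was benzyloxy in compound 1 (6.67 nM) where compound 3 carries fluoro (3.09 nM), and the one evidence at hand concerns the stereocentre and gives no explanation for the hydroxy and fluoro pair.

From the compounds shown here alone, whether an amine, a carboxylic acid, a methoxy group or a longer chain on this aromatic carbon would stay level with hydroxy and fluoro remains open. The compounds shown also leave open how hydroxy would read with the stereocentre drawn without a configuration, as it is in compound 2, so the size of that stereo step with hydroxy in place is unknown.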